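Carboxy in place of tetrazole on a fused quinoline-type core

The compounds below may be only part of what the source reports. "The series", "measured", "known", "first", "only" and "open" are said of these compounds alone.

Measured compounds in a functional assay on the whole organism (strain Sprague-Dawley) for inhibition, with Rattus norvegicus as the target; on this read-out higher numbers stand for an effect only at larger amounts of compound and lower numbers for an effect already at smaller amounts:
Compound 1 `COc1ccc2ncc(-c3nn[nH]n3)cc2c1` gives 10 mg/kg.
Compound 2 `c1ccc2ncc(-c3nn[nH]n3)cc2c1` gives 10 mg/kg.
Compound 3 `c1nc2ccc(C3CCCCC3)cc2cc1-c1nn[nH]n1` gives 5 mg/kg.

Compound 3 has the lowest number of the three, but its steps to compound 1 and compound 2 are within the scatter, so no order among them can be claimed. The change to compound 4 `O=C(O)c1cnc2ccc(C3CCCCC3)cc2c1` is carboxy in place of 2H-tetrazol-5-yl on an aromatic carbon. The measured steps, no change at the digits printed from compound 1 to compound 2 (within the scatter), a 2.0-fold lower number from compound 1 to compound 3 (0.30 log units; within the scatter) and a 2.0-fold lower number from compound 2 to compound 3 (0.30 log units; within the scatter), all concern the methoxy, hydrogen and cyclohexyl exchanges and say nothing about replacing the 2H-tetrazol-5-yl. For the measured compounds named here, no step in the data bears on this change, so compound 4 is expected to show a 1.4-fold higher number from compound 3 to compound 4 (0.15 log units; within the scatter), meaning no step beyond the scatter, with wide uncertainty. Compound 4 is estimated at 7 mg/kg, in the range 2 mg/kg to 25 mg/kg.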

Compound 4, minimum effective dose: > 25 mg/kg
Compound 4: no number, only a limit; the forecaster's own chance of this, stated with the estimate: 15%; at least 3.5-fold (0.55 log units) between middle value and limit.
By their numbers in this assay, from the lowest: compounds 3, 1 and 2 (each within the scatter of the next). At a limit, above all of these: compound 4.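

In this assay compound 4 gives > 25 mg/kg, which is a limit of the assay and not a number. For the compounds shown here, putting carboxy in place of 2H-tetrazol-5-yl on this aromatic carbon gives an at least 5.0-fold higher number from compound 3 to compound 4 (0.69 log units; beyond the scatter), the only step here beyond the scatter, as the methoxy, hydrogen and cyclohexyl exchanges all stayed within it. The true size of this step remains unknown: the limit of > 25 mg/kg in this assay, at which 1 of the 4 values shown sits.

On these data alone, whether an amide or a methyl ester at this position would perform like 2H-tetrazol-5-yl remains open. So does whether carboxy would give the same result with methoxy or hydrogen in place of cyclohexyl.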